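A few compounds are considered here, and "the series" means these few. Any claim that something is new, unique, unknown or untested is made for them only; others in the source may bear on it.

Three compounds built on a shared core have been run through an ADME assay on HepG2 cells (Homo sapiens) for cytotoxicity, read by MTT assay, with a stated time of 24 h; on this read-out lower numbers stand for higher toxicity in this test and higher numbers for lower toxicity in this test. Compound 1 `OCCCc1cn(-c2ccnc3cc(Cl)ccc23)nn1` gives 151000 nM. For compound 2 `CC(C)(C)c1ccc(C(=O)OCCCc2cn(-c3ccnc4cc(Cl)ccc34)nn2)cc1` the result is only a limit of the assay, > 2230000 nM. For compound 3 `CCc1ccccc1C(=O)OCc1cn(-c2ccnc3cc(Cl)ccc23)nn1` the result is likewise only a limit, > 2550000 nM. Compound 3 thus stands among the two compounds for which this assay reports no number; it sits at the limit of > 2550000 nM in this assay, at which 1 of the 3 values shown sits. Compound 4 `O=C(OCc1cn(-c2ccnc3cc(Cl)ccc23)nn1)c1ccc(Cl)cc1` has not yet been measured. It differs from compound 3 in one place: 4-chlorophenyl in place of 2-ethylphenyl on a carbonyl carbon. No measured step connects two of the shown compounds, so the size of this step cannot be read from the data. The change is expected to move the read-out in this assay no further than the usual scatter, and compound 4 is estimated at 2500000 nM (range 800000 nM to 5000000 nM). That estimate is expected to mean an at least 1.0-fold lower number from compound 3 to compound 4 (0.00 log units; that floor lies within the scatter).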

Compound 4, half-maximal cytotoxic concentration: 484000 nM
For compound 4 the middle estimate is 5.2-fold (0.71 log units) above the measured one; measured number below the stated range.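

In this assay, 4-chlorophenyl in place of 2-ethylphenyl on a carbonyl carbon gives an at least 5.2-fold lower number from compound 3 to compound 4 (0.72 log units; beyond the scatter). This is the first step that can be read among these compounds, and it shows that the group at this place can move the read-out beyond the scatter. The result for compound 3 is only a limit: the limit of > 2550000 nM in this assay, at which 1 of the 4 values shown sits.

The two groups differ in more than one respect, so the compounds shown do not separate the arrival of the chlorine from the loss of the ethyl. Going by these compounds, how a plain phenyl or an amine-bearing ring would read at this place remains open.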